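This account rests on a few compounds, and the source may have more. Where it says the series, first, only, none or still open, it means among the compounds named here.

Compound 1 `CCCCC[C@H](CN(O)C=O)C(=O)NCNC(=O)c1ccc(-c2ccccc2)o1`: 25 nM
Compound 2 `CCCCC[C@H](CN(O)C=O)C(=O)NCNC(=O)c1cc2cccc(OC)c2o1`: 160 nM
Compound 3 `CCCCC[C@@H](C(=O)NCNC(=O)c1cc2cccc(OC)c2o1)[C@@H](CC)N(O)C=O`: 126 nM

Of the compounds shown here, three have been measured in an assay on CHO cells for inhibition of bone morphogenetic protein 1 (Homo sapiens), with stated times of 10 min and 60 min; on this read-out higher numbers stand for weaker inhibition and lower numbers for stronger inhibition. Compound 1 gives the lowest number of the three, with 25 nM, and compound 2 gives 160 nM; the difference between the two cores is not broken down here. Relative to compound 2 the change is ethyl in place of hydrogen on a saturated chain carbon bound to an amide-type nitrogen and a saturated chain carbon, and compound 3 gives 126 nM, so that a 1.3-fold lower number from compound 2 to compound 3 (0.10 log units; within the scatter).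

The unmeasured compound 4 `CCCCC[C@@H](C(=O)NCNC(=O)c1ccc(-c2ccccc2)o1)[C@@H](CC)N(O)C=O` bears the same change on the core of compound 1: ethyl in place of hydrogen on a saturated chain carbon bound to an amide-type nitrogen and a saturated chain carbon. Because the step of a 1.3-fold lower number from compound 2 to compound 3 (0.10 log units; within the scatter) stayed within the scatter, the same kind of change on compound 1 is expected to move the number only a little. The estimate for compound 4 therefore rests on compound 1 and its value 25 nM, and the expected step is a 1.1-fold lower number from compound 1 to compound 4 (0.06 log units; within the scatter). Compound 4 is thus estimated at 22 nM in this assay, with a likely range from 8 nM to 60 nM.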

Compound 4, half-maximal inhibitory concentration: 32 nM
Compound 4: the middle estimate sits 1.5-fold (0.16 log units) below what was measured, within the range that was stated.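

In this assay, ethyl in place of hydrogen on a saturated chain carbon bound to an amide-type nitrogen and a saturated chain carbon gives a 1.3-fold higher number from compound 1 to compound 4 (0.11 log units; within the scatter). Set beside the same change on the other core, the two steps do not differ beyond the scatter: the same change on two cores in this assay, a 1.3-fold lower number (0.10 log units; within the scatter) from compound 2 to compound 3 and a 1.3-fold higher number (0.11 log units; within the scatter) from compound 1 to compound 4, 1.6-fold (0.21 log units) apart, within the scatter of two such steps On both cores shown the change therefore carries over as one that leaves the number within the scatter, but this rests on two pairs of compounds in a single assay and does not show that it would hold on any further core.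

As far as these compounds go, whether a longer chain such as butyl, or an amine, on that same carbon would leave the number as undisturbed as ethyl does remains open. The compounds shown also leave open how the ethyl change would behave on a core carrying a carboxylic acid.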